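The source may hold more compounds than are shown below. What is called first, only, known or untested is meant among the compounds shown, and "the series" means these compounds.

Measured in a functional assay on SF-295 cells (Homo sapiens) for inhibition, read by sulforhodamine B assay, with a stated time of 48 h; on this read-out lower numbers stand for stronger inhibition of growth and higher numbers for weaker inhibition of growth:

compound 1, `N=C(N)c1ccc(-c2ccc(-c3cc(Cl)cc(Cl)c3)s2)s1`: 1960 nM
compound 2, `COc1ccc(-c2ccc(-c3ccc(C(=N)N)o3)o2)cc1`: 1680 nM
compound 3, `N=C(N)c1ccc(-c2ccc(-c3ccc(Cl)cc3)s2)s1`: 1630 nM

Compound 2 gives the second highest of the three numbers. Its nearest neighbour is compound 3 and its furthest is compound 1, and both gaps sit within the scatter, so the three measured compounds cannot be ranked against one another in this assay.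

Compound 4, `N=C(N)c1ccc(-c2ccc(-c3ccccc3)o2)o1`, differs from compound 2 in one place: hydrogen in place of methoxy on an aromatic carbon. Going by the values given here, no pair of measured compounds isolates this change, so nothing measured bears directly on its size. The expected step from compound 2 to compound 4 in this assay is a 1.1-fold higher number from compound 2 to compound 4 (0.03 log units; within the scatter), not beyond the scatter in either direction. Compound 4 is estimated at 1800 nM, with a range from 700 nM to 4500 nM.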

Compound 4, concentration for 50% growth inhibition: 1810 nM
Compound 4: middle estimate off by 1.0-fold (0.00 log units), on the low side, and the stated range covers the measured number.
By their numbers in this assay, from the lowest: compounds 3, 2, 4 and 1 (each within the scatter of the next).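

In this assay, going by these compounds alone, hydrogen in place of methoxy on the aromatic carbon para to a large group gives a 1.1-fold higher number from compound 2 to compound 4 (0.03 log units; within the scatter) as the first step to isolate this position. Across this change, the read-out does not separate the two compounds, so methoxy is not required here for the growth inhibition seen with compound 2. No evidence is available to explain this result.

Going by these compounds, whether an amine or a carboxylic acid at this position would shift the number beyond the scatter remains open. So does whether the same replacement behaves alike on the core of compound 3.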